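Chloro added to the fluorophenyl ring of the styryl sulfone

The compounds below may be only part of what the source reports. "The series", "measured", "known", "first", "only" and "open" are said of these compounds alone.

Measured so far:
compound 1 `O=S(=O)(/C=C/c1ccc(F)cc1)Cc1ccc(Nc2ncnc3ccccc23)cc1` — 10 nM
compound 2 `O=S(=O)(/C=C/c1ccc(Cl)c(Cl)c1)Cc1ccc(Nc2ncnc3ccccc23)cc1` — 11000 nM

Among the measured compounds shown here, in a functional assay on U-251 cells (Homo sapiens) (a higher number here means a weaker inhibitor of growth, a lower number a stronger inhibitor of growth), compound 1 gives 10 nM, the lowest of the two numbers; the only other measured compound, compound 2, gives 11000 nM. For the measured compounds named here, the single step between them, a 1100-fold higher number from compound 1 to compound 2 (3.04 log units; beyond the scatter), is the sole guide for the series.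

Compound 3 `O=S(=O)(/C=C/c1ccc(F)cc1Cl)Cc1ccc(Nc2ncnc3ccccc23)cc1` differs from compound 1 by chloro in place of hydrogen on an aromatic carbon; the fluoro group is kept and the new chloro sits ortho to a large group, meta to that fluoro group. The step from compound 1 to compound 2 also brought chlorine onto this ring, but at another place and with the fluoro replaced, so it bears on compound 3 only loosely. A weakening is expected in this assay, though smaller than that step and uncertain. Compound 3 is therefore expected to give 300 nM (range 30 nM to 3000 nM), a step of a 30-fold higher number from compound 1 to compound 3 (1.48 log units; beyond the scatter).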

Compound 3, concentration for 50% growth inhibition: 100000 nM
Compound 3: the middle estimate sits 330-fold (2.52 log units) below what was measured, outside the stated range (above it).
By their numbers in this assay, from the lowest: compound 1; then compound 2; then compound 3.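

In this assay, a single chloro on an aromatic carbon, ortho to a large group, shifts the read-out by a 10000-fold higher number from compound 1 to compound 3 (4.00 log units; beyond the scatter), so this one added atom is enough to nearly abolish growth inhibition even with the fluoro group kept. Losing the fluoro group is therefore not required for a large loss, and the ring substitution pattern matters beyond the mere presence of chlorine: there is still a 9.1-fold higher number from compound 2 to compound 3 (0.96 log units; beyond the scatter), although that pair differs in both the fluoro group and the place of chlorine. Nothing available accounts for the size of these losses.

On these data alone, whether the loss belongs to chloro itself or to any group at this position stays open; a methyl or a methoxy there would separate the two. Also open, as far as these compounds go, is how chloro behaves at the other ring carbons with the fluoro group kept.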